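This account rests on a few compounds, and the source may have more. Where it says the series, first, only, none or still open, it means among the compounds named here.

Measured so far:
compound 1 `O=c1ccc2cc(OCc3cc(-c4ccccc4Cl)no3)ccc2o1` — compound 1 gives "not determined" (no result reported).
compound 2 `O=c1ccc2cc(OCc3cc(-c4cccc(Cl)c4)no3)ccc2o1` — compound 2 gives 32500 nM.
compound 3 `O=c1ccc2cc(OCc3cc(-c4ccc(Cl)cc4)no3)ccc2o1` — compound 3 gives 44500 nM.

In a functional assay on COLO 205 cells (Homo sapiens) for cytotoxicity, read by MTT assay, with a stated time of 48 h (a lower number here means a stronger inhibitor, a higher number a weaker inhibitor), compound 3 holds the highest of the two numbers available; the nearest is compound 2, and the step of a 1.4-fold higher number from compound 2 to compound 3 (0.14 log units; within the scatter) lies within the scatter, so the two cannot be ordered. Compound 1 brings no number to the comparison.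

Compound 4 `O=c1ccc2cc(OCc3cc(-c4ccc([N+](=O)[O-])cc4)no3)ccc2o1` differs from compound 3 by nitro in place of chloro on an aromatic carbon — nitro in place of chloro on an aromatic carbon, para to a large group. For the measured compounds named here, no measured step exchanges a chloro for a nitro. Going by the values given here, the only step in hand, a 1.4-fold higher number from compound 2 to compound 3 (0.14 log units; within the scatter), moves the chloro to another ring position and stays within the scatter, which gives no lead on the present exchange in either direction. The expectation is therefore a step no larger than the scatter in this assay. The estimate for compound 4 is 40000 nM with a range of 15000 nM to 110000 nM. This estimate corresponds to an expected step of a 1.1-fold lower number from compound 3 to compound 4 (0.05 log units; within the scatter).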

Compound 4, half-maximal inhibitory concentration: 47800 nM
The estimate for compound 4 lay 1.2-fold (0.08 log units) below the measured number, within the range that was stated.
By their numbers in this assay, from the lowest: compounds 2, 3 and 4 (each within the scatter of the next).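

In this assay, for the compounds shown here, the step so far only moved the chloro, whereas here the group itself is exchanged at the carbon para to a large group, with a 1.1-fold higher number from compound 3 to compound 4 (0.03 log units; within the scatter). Nitro, with 3 heavy atoms and hydrogen-bond acceptors that chloro lacks, therefore leaves the number within the scatter at this position, and a 1.5-fold higher number from compound 2 to compound 4 (0.17 log units; within the scatter) is also within the scatter, so compounds 2, 3 and 4 cannot be ordered. No measurement available here explains this absence of a separation.

As far as these compounds go, whether an amine or a carboxylic acid on this same aromatic carbon would give a step beyond the scatter remains open. Also open, from the compounds shown here alone, is whether a change elsewhere in the shared core would separate the numbers in this assay.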